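Notes on carbonyl-carbon variation and a nitrile analogue

The source may hold more compounds than are shown below. What is called first, only, known or untested is meant among the compounds shown, and "the series" means these compounds.

Compound 1 `COc1ccc2c(c1)OC(c1cc(OC)c(OC)c(OC)c1)C(C(C)=O)=C2` in a functional assay for inhibition of nuclear factor NF-kappa-B complex (Homo sapiens) (a higher number here means a weaker inhibitor, a lower number a stronger inhibitor), gives 14100 nM.
Compound 2 `COc1ccc2c(c1)OC(c1cc(OC)c(OC)c(OC)c1)C(C(=O)OC(C)(C)C)=C2` gives 14100 nM.
Compound 3 `COc1ccc2c(c1)OC(c1cc(OC)c(OC)c(OC)c1)C(C(N)=O)=C2` shows only a limit of the assay, > 50000 nM.

Compound 3 therefore stands at the limit of > 50000 nM in this assay, at which 1 of the 3 values shown sits, with no number behind it. Compound 4 `COc1ccc2c(c1)OC(c1cc(OC)c(OC)c(OC)c1)C(C#N)=C2` differs from compound 3 by cyano in place of carbamoyl on a double-bonded ring carbon. Going by the values given here, no measured step covers cyano in place of carbamoyl directly; the nearest are an at least 3.5-fold higher number from compound 1 to compound 3 (0.54 log units; beyond the scatter) and an at least 3.5-fold higher number from compound 2 to compound 3 (0.54 log units; beyond the scatter), both running into the limit, while no change at the digits printed from compound 1 to compound 2 (within the scatter). The carbamoyl thus sits apart from the other two carbonyl groups, and compound 4 lacks a precedent of its own. Compound 4 is expected at 25000 nM, within 8000 nM to 60000 nM. That expectation corresponds to an at least 2.0-fold lower number from compound 3 to compound 4 (0.30 log units; that floor lies within the scatter), with a real chance that only a limit is again recorded.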

Compound 4, half-maximal inhibitory concentration: 3400 nM
Estimate against measurement, compound 4: 7.4-fold (0.87 log units) above; measured number outside the range, below it.
By their numbers in this assay, from the lowest: compound 4; then compounds 1 and 2 (each within the scatter of the next). At a limit, above all of these: compound 3.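

In this assay, cyano on the double-bonded ring carbon separates from both carbonyl groups that gave numbers: a 4.1-fold lower number from compound 1 to compound 4 (0.62 log units; beyond the scatter) and a 4.1-fold lower number from compound 2 to compound 4 (0.62 log units; beyond the scatter). Against carbamoyl the change reads an at least 14-fold lower number from compound 3 to compound 4 (1.16 log units; beyond the scatter), which is only a floor, since compound 3 is held at a limit of the assay: the limit of > 50000 nM in this assay, at which 1 of the 4 values shown sits. This position therefore responds to the group it carries, and compound 4 has the lowest number of the four. Going by these compounds, whether that holds beyond cyano remains open; a carboxylic acid or a tetrazole at this carbon would test it.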